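This account rests on a few compounds, and the source may have more. Where it says the series, first, only, none or still open, it means among the compounds named here.

Of the compounds shown here, three built on one shared core have been measured in an assay on isolated protein for inhibition of Dihydrofolate reductase (Mus musculus); a higher number here means a more potent compound, by a factor of ten per unit of this negative logarithm, a lower number a less potent compound. Compound 1 `CC1(C)N=C(N)N=C(N)N1c1ccc(OCCCNC(=O)c2ccc(S(=O)(=O)F)cc2)c(Cl)c1` gives 7.34. Compound 2 `CC1(C)N=C(N)N=C(N)N1c1ccc(SCC(=O)Nc2ccc(S(=O)(=O)F)cc2)cc1` gives 7.52. Compound 3 `CC1(C)N=C(N)N=C(N)N1c1ccc(OCCOCCOc2ccc(S(=O)(=O)F)cc2)c(Cl)c1` gives 7.14. Compound 2 shows the highest of the three numbers, though the gap to compound 1 lies within the usual scatter of this kind of measurement, so the two cannot be ranked against each other; only the gap to compound 3 lies beyond that scatter.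

Compound 4 `CC1(C)N=C(N)N=C(N)N1c1ccc(SCC(=O)Nc2ccc(S(=O)(=O)F)cc2)c(Cl)c1` has not yet been measured in this assay. It differs from compound 2 in one place: chloro in place of hydrogen on an aromatic carbon. For the measured compounds named here, no single-step comparison between two measured compounds covers this particular change, so no measured step can be called on. The three measured values all lie close together despite their differences in the linker and in the presence or absence of a chloro group, which suggests that a single chloro group is unlikely to move the number far.

The expected step from compound 2 to compound 4 in this assay is a number 0.08 log units higher from compound 2 to compound 4 (within the scatter), a small change that may well sit within the scatter. Compound 4 is therefore estimated at 7.6, with a likely range from 7.2 to 8.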

Compound 4, logarithm of the reciprocal of the active concentration, log(1/C): 7.42
The estimate for compound 4 lay 0.18 log units above the measured number; the range from low to high includes it.
By their numbers in this assay, from the lowest: compounds 3, 1, 4 and 2 (each within the scatter of the next, the first and the last beyond it).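

In this assay, putting chloro in place of hydrogen on an aromatic carbon, ortho to a large group and meta to a large group, gives a number 0.10 log units lower from compound 2 to compound 4 (within the scatter), so the two compounds cannot be told apart and this single chlorine atom has no readable effect in this setting. For the compounds shown here, this is the first reading of the change on its own, since compound 1 and compound 3 also carry chloro but have different linkers from compound 2, which left the contribution of the chlorine mixed with that of the chain. No measurement shown here offers an explanation for this result.

Going by these compounds, whether other groups at the same position would also leave the number within the scatter remains open, for example fluoro, methyl, methoxy or an amine. Going by these compounds alone, it also remains open whether chloro in place of hydrogen would read the same way on a compound with a different linker, such as a longer chain, because the only pair that isolates this change is the one that shares the linker of compound 2.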